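This account rests on a few compounds, and the source may have more. Where it says the series, first, only, none or still open, it means among the compounds named here.

Measured so far in a functional assay on THP-1 cells (Homo sapiens) for cytotoxicity, read by MTT assay, with a stated time of 24 h; on this read-out lower numbers stand for stronger inhibition and higher numbers for weaker inhibition
- compound 1 `COc1ccc(/C=C2\CN(C)C/C(=C\c3ccccc3F)C2=O)cc1` gives 15400 nM
- compound 2 `CN1C/C(=C\c2ccc(C(C)(C)C)cc2)C(=O)/C(=C/c2ccccc2F)C1` gives 13400 nM
- compound 3 `COc1cc(/C=C2\CN(C)C/C(=C\c3ccc(F)cc3)C2=O)cc(OC)c1` gives 5040 nM

Compound 3 (5040 nM) stands lowest of the three, beyond the scatter from both others, while compound 1 and compound 2 lie within the scatter of each other. Next comes compound 4 `COc1cc(/C=C2\CN(C)C/C(=C\c3ccc(Cl)cc3Cl)C2=O)cc(OC)c1` with the change 2,4-dichlorophenyl in place of 4-fluorophenyl on a double-bonded chain carbon bound to a double-bonded ring carbon. Going by the values given here, the only measured step (a 1.1-fold lower number from compound 1 to compound 2 (0.06 log units; within the scatter)) replaces methoxy with tert-butyl, stays within the scatter and does not touch this group, so its guidance is weak. In this assay no shift beyond the scatter is expected (expected step a 1.3-fold lower number from compound 3 to compound 4 (0.10 log units; within the scatter)). The estimate for compound 4 is 4000 nM (expected range 1500 nM to 11000 nM).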

Compound 4, half-maximal inhibitory concentration: 6070 nM
For compound 4 the middle estimate is 1.5-fold (0.18 log units) below the measured one, within the range that was stated.
By their numbers in this assay, from the lowest: compounds 3 and 4 (each within the scatter of the next); then compounds 2 and 1 (each within the scatter of the next).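

In this assay the first change shown at this position, on a double-bonded chain carbon bound to a double-bonded ring carbon, stays within the scatter (a 1.2-fold higher number from compound 3 to compound 4 (0.08 log units; within the scatter)). Here, 2,4-dichlorophenyl and 4-fluorophenyl cannot be told apart on the shared core of compound 3. No measured evidence explains this result.

Open, from the compounds shown here alone, is whether a phenyl group carrying an amine or a carboxylic acid at this position would shift the number beyond the scatter. Also open, going by these compounds, is what 4-chlorophenyl, with a single chlorine, would give.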